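The source may report more compounds than this note shows. Statements on the series, on what has been measured and on what is new or still open speak of the compounds shown alone.

Measured so far:
- compound 1 `COc1ccc(NC(=O)NCCNS(=O)(=O)c2ccc(-c3ccccc3Oc3ccc([N+](=O)[O-])cc3)s2)cc1`: > 50000 nM
- compound 2 `O=S(=O)(NCCNC(=S)Nc1cc(C(F)(F)F)cc(C(F)(F)F)c1)c1ccc(-c2ccccc2OCc2ccccc2)s1`: 2100 nM
- compound 3 `O=C(NCCNS(=O)(=O)c1ccc(-c2ccccc2OCc2ccccc2)s1)Nc1cc(C(F)(F)F)cc(C(F)(F)F)c1`: 11400 nM

In a functional assay on HL-60 cells (Homo sapiens) for inhibition, read by CCK-8 assay, with a stated time of 48 h (a lower number here means a stronger inhibitor, a higher number a weaker inhibitor), compound 1 gives only a limit, > 50000 nM, not a number. Compound 2 gives 2100 nM in this assay. Compound 3 gives 11400 nM in this assay, the higher of the two numbers measured, and the gap between the two values lies beyond the usual scatter. Among the compounds with values here, no step between two measured compounds differing in only one place is available here, so compound 4 `O=C(NCCNS(=O)(=O)c1ccc(-c2ccccc2O[C@H]2CC[C@H](O)CC2)s1)Nc1cc(C(F)(F)F)cc(C(F)(F)F)c1` has to be judged from the change itself: 4-hydroxycyclohexyl in place of benzyl on an oxygen on an aromatic ring. A benzyl ether is thus replaced by a (4-hydroxycyclohexyl)oxy group at the same place. Within the data shown here, with no measured step to lean on, a moderate loss is expected, in the direction of a higher number, and the step of a 1.8-fold higher number from compound 3 to compound 4 (0.24 log units; within the scatter) is the estimated size. Compound 4 is expected to give about 20000 nM in this assay, most likely between 5000 nM and 50000 nM.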

Compound 4, half-maximal inhibitory concentration: 7100 nM
Compound 4: the middle estimate sits 2.8-fold (0.45 log units) above what was measured; low and high end bracket the measured number.
By their numbers in this assay, from the lowest: compound 2; then compounds 4 and 3 (each within the scatter of the next). At a limit, above all of these: compound 1.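

In this assay the exchange gives a 1.6-fold lower number from compound 3 to compound 4 (0.21 log units; within the scatter), so on this oxygen on an aromatic ring, 4-hydroxycyclohexyl and benzyl cannot be told apart. The two groups have the same number of heavy atoms, but the entering group has a non-aromatic ring, a hydrogen-bond donor, a hydrogen-bond acceptor and two defined stereocentres. An aromatic ring at this place is therefore not needed for a value in this range, at least with this urea and the rest of compound 3 held constant.

From the compounds shown here alone, whether an amine or a carboxylic acid in place of the hydroxyl on the cyclohexyl ring, or the opposite arrangement of the two stereocentres, would read the same remains open. No measured property shown here bears on why these two groups read alike.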